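Methyl in place of hydrogen on the sulfonyl aryl ring

A few compounds are considered here, and "the series" means these few. Any claim that something is new, unique, unknown or untested is made for them only; others in the source may bear on it.

Of the compounds shown here, three sharing one core have been measured in an ADME assay on microsomes from liver (Homo sapiens) for metabolic stability, tested at 2.5 uM; on this read-out higher numbers stand for fast clearance and lower numbers for slow clearance. Compound 1 `COc1ccc(-c2c(S(=O)(=O)c3ccc(C)c(F)c3)cnc3c(F)cccc23)cc1` gives 3.27 mL/min. Compound 2 `O=S(=O)(c1ccc(F)c(Cl)c1)c1cnc2c(F)cccc2c1-c1ccc(Cl)cc1` gives 0.01 mL/min, and compound 3 `O=S(=O)(c1cccc(F)c1)c1cnc2c(F)cccc2c1-c1ccc(Cl)cc1` gives 0.62 mL/min, which puts compound 3 second highest of the three numbers, a lower number than compound 1 and far above compound 2. Going by the values given here, the only single-point step measured so far is a 62-fold higher number from compound 2 to compound 3 (1.79 log units; beyond the scatter), which concerns the same ring but a different part of it.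

Compound 4 `Cc1ccc(S(=O)(=O)c2cnc3c(F)cccc3c2-c2ccc(Cl)cc2)cc1F` has not yet been measured. It differs from compound 3 by methyl in place of hydrogen on an aromatic carbon. Among the compounds with values here, no measured step speaks directly to this change; compound 1 carries the same 3-fluoro-4-methylphenyl ring but also a different group on the core, so its value only hints that such a ring can sit with a high number. A modest rise in this assay is therefore expected, as a 1.9-fold higher number from compound 3 to compound 4 (0.29 log units; within the scatter). Compound 4 is estimated at 1.2 mL/min, within 0.3 mL/min to 4 mL/min.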

Compound 4, intrinsic clearance in a liver preparation (reported as CLH), per the amount of preparation that the assay uses: 2.2 mL/min
Compound 4: the middle estimate sits 1.8-fold (0.26 log units) below what was measured, and the stated range covers the measured number.
By their numbers in this assay, from the lowest: compound 2; then compound 3; then compounds 4 and 1 (each within the scatter of the next).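

In this assay, methyl para to a large group and ortho to a fluoro group now has a step of its own, a 3.5-fold higher number from compound 3 to compound 4 (0.55 log units; beyond the scatter), which shows that this single added carbon moves the number beyond the scatter. Against the 3-chloro-4-fluorophenyl ring, the 3-fluoro-4-methylphenyl ring gives a 220-fold higher number from compound 2 to compound 4 (2.34 log units; beyond the scatter), so this position belongs to the largest step measured in the series. With the 3-fluoro-4-methylphenyl ring held constant, chloro in place of methoxy on an aromatic carbon gives a 1.5-fold lower number from compound 1 to compound 4 (0.17 log units; within the scatter), a step that stays within the scatter, so the high number seen with this ring holds with either group.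

Nothing at hand explains why the number responds to this change. The compounds shown leave open how an ethyl or a hydroxymethyl group at this position would read in this assay.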